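This account rests on a few compounds, and the source may have more. Where it says the series, first, only, none or still open, it means among the compounds named here.

Working notes on the series.

In an ADME assay on the whole organism with Oryza sativa as the target, tested at 1 uM (on this read-out lower numbers stand for a stronger effect and higher numbers for a weaker effect at the one concentration tested), compound 1 `C[C@@H](NC(=O)Nc1ccccc1Br)c1ccccc1` gives 100%. Compound 3 `C[C@@H](NC(=O)Nc1ccccc1I)c1ccccc1` carries iodo in place of bromo on an aromatic carbon and in this assay compound 3 gives 100%; the step is no change at the digits printed from compound 1 to compound 3 (within the scatter). Compound 2 `C[C@@H](NC(=O)Nc1cccc(Br)c1)c1ccccc1` gives 100% in this assay, level with compounds 1 and 3; how the core of compound 2 differs from the core of compound 1 is not broken down here. Compound 4 `C[C@@H](NC(=O)Nc1cccc(I)c1)c1ccccc1` awaits measurement in this assay. It differs from compound 2 by iodo in place of bromo on an aromatic carbon. This is the same kind of change as from compound 1 to compound 3, though there the place was ortho to a large group and here it is meta to a large group. Because no change at the digits printed from compound 1 to compound 3 (within the scatter) the expected step is no change at the digits printed from compound 2 to compound 4 (within the scatter). Compound 4 is estimated at 100%, between 90% and 100%.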

Compound 4, a percentage reported as activity, at one concentration (the size of the read-out at that concentration, not a potency): 75%
The estimate for compound 4 lay 25 percentage points above the measured number; the measured number lies below the stated range.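

Iodo in place of bromo on an aromatic carbon does not carry over as a fixed step between the two cores in this assay: the same change on two cores in this assay, no change at the digits printed (within the scatter) from compound 1 to compound 3 and a number 25 percentage points lower (beyond the scatter) from compound 2 to compound 4, 25 percentage points apart, beyond the scatter of two such steps. With the group meta to a large group, the change gives a number 25 percentage points lower from compound 2 to compound 4 (beyond the scatter), so a step read on one core cannot simply be transferred to the other in this series. These two pairs do not show why the steps differ, and a read-out at one concentration gives no potency.

The compounds shown leave open how other groups at the same place, such as chloro, methoxy or an amine, would read. From the compounds shown here alone, whether the step on the core of compound 2 extends to other cores also stays open.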